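The source may hold more compounds than are shown below. What is called first, only, known or untested is meant among the compounds shown, and "the series" means these compounds.

Measured in a functional assay on A-431 cells (Homo sapiens) for antiproliferative activity, read by MTT assay, with a stated time of 72 h; a higher number here means a weaker inhibitor, a lower number a stronger inhibitor:

- Compound 1 `CN1CCN(c2ccc(Nc3ncc4nc(Nc5ccccc5)n([C@H]5CCN(S(=O)(=O)C6CC6)C5)c4n3)cc2)CC1` gives 1670 nM
- Compound 2 `CN1CCN(c2ccc(Nc3ncc4nc(Nc5ccc(F)cc5)n([C@@H]5CCCN(C(=O)CO)C5)c4n3)cc2)CC1` gives "not determined" (no result reported)

Compound 2 has no number to stand on, and its entry reads "not determined" (no result reported). Compound 3 `CN1CCN(c2ccc(Nc3ncc4nc(Nc5ccc(F)cc5)n([C@H]5CCN(S(=O)(=O)C6CC6)C5)c4n3)cc2)CC1` differs from compound 2 in one place. It has 1-(cyclopropylsulfonyl)pyrrolidin-3-yl in place of 1-((hydroxymethyl)carbonyl)piperidin-3-yl on an aromatic nitrogen. A step from compound 2 therefore cannot be sized. Compound 1 carries the same 1-(cyclopropylsulfonyl)pyrrolidin-3-yl and gives 1670 nM, and no shift beyond the scatter from that value is expected in this assay. The expected value for compound 3 is 1300 nM, within an estimated range of 400 nM to 4000 nM.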

Compound 3, half-maximal inhibitory concentration: 1670 nM
Beside the measured number, compound 3's estimate is 1.3-fold (0.11 log units) below it, within the range that was stated.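

In this assay, fluoro in place of hydrogen on an aromatic carbon gives no change at the digits printed from compound 1 to compound 3 (within the scatter). With 1-(cyclopropylsulfonyl)pyrrolidin-3-yl held constant on the aromatic nitrogen, this single change on the anilino-type group leaves the read-out within the scatter, while compound 2 has no result and steps from it cannot be read. No other measurement bears on this result.

From the compounds shown here alone, whether chloro or methoxy in place of the fluoro would read the same stays open. So does the effect of a dimethylamino group or a longer alkyl chain in place of the cyclopropyl on the sulfonyl.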